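A few compounds are considered here, and "the series" means these few. Any claim that something is new, unique, unknown or untested is made for them only; others in the source may bear on it.

The series shares one core, shown by compound 1 `COc1cccc(N2C(=O)N/C(=C\c3ccc(O)cc3)C2=O)c1` and compound 2 `Cc1cccc(N2C(=O)N/C(=C\c3ccc(O)cc3)C2=O)c1`, which differ by a single substituent on the same aromatic carbon. In a functional assay on NCI-H292 cells (Homo sapiens) for antiproliferative activity (on this read-out higher numbers stand for weaker inhibition and lower numbers for stronger inhibition), compound 1 gives only a limit, > 200000 nM. In this assay compound 2 likewise gives only a limit, > 200000 nM. The step that the two limits leave unreadable from compound 1 to compound 2 therefore cannot be sized, because both values sit at the limit of > 200000 nM in this assay, at which 2 of the 2 values shown sit. On the numbers shown compound 2 thus stands at the limit, without a measured inhibitory concentration, and no ordering against compound 1 can be read. Compound 3 `O=C(O)c1cccc(N2C(=O)N/C(=C\c3ccc(O)cc3)C2=O)c1` carries the change (carboxy in place of methyl on an aromatic carbon). Among the compounds with values here, only one measured step bears on this change, and it is unreadable, so it supplies no direction beyond the scatter. For compound 3 the expected step that the limit leaves unreadable from compound 2 to compound 3 is accordingly small and most likely hidden behind the same limit. Compound 3 is therefore expected to give about 300000 nM in this assay, within a range from 100000 nM to 1000000 nM.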

Compound 3, half-maximal inhibitory concentration: > 200000 nM
Compound 3 ended at the assay's limit; the forecaster's own chance of this, stated with the estimate: 85%; the middle value is on the limit's open side.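

Compound 3 also gives only a limit in this assay, so no step among compound 1, compound 2 and compound 3 can be read, because all three values sit at the same limit: the limit of > 200000 nM in this assay, at which 3 of the 3 values shown sit.

The compounds shown leave open whether methoxy, methyl and carboxy differ at all in their effect on this read-out.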